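A few compounds are considered here, and "the series" means these few. Any claim that something is new, unique, unknown or untested is made for them only; others in the source may bear on it.

Among the measured compounds shown here, compound 2 `COc1cc(-c2nnc(SCC(=O)c3ccc(F)cc3)n2N2C(=O)c3ccccc3C2=O)cc(OC)c1OC` is one of two compounds so far measured in a functional assay on A549 cells (Homo sapiens) for cytotoxicity, read by MTT assay, with a stated time of 48 h; a higher number here means a weaker inhibitor, a lower number a stronger inhibitor. In this assay compound 2 gives > 200000 nM, which is a limit of the assay rather than a number (the limit of > 200000 nM in this assay, at which 1 of the 2 values shown sits). The other measured compound, compound 1 `COc1ccc(C(=O)CSc2nnc(-c3cc(OC)c(OC)c(OC)c3)n2N2C(=O)c3ccccc3C2=O)cc1`, gives 30000 nM in this assay. The step from compound 1 to compound 2, fluoro in place of methoxy on an aromatic carbon, reads an at least 6.6-fold higher number from compound 1 to compound 2 (0.82 log units; beyond the scatter). Compound 3 `COc1cc(-c2nnc(SCC(=O)c3ccc(Br)cc3)n2N2C(=O)c3ccccc3C2=O)cc(OC)c1OC` has not yet been measured. It differs from compound 2 in a single place: bromo in place of fluoro on an aromatic carbon. For the measured compounds named here, no measured step exchanges one halogen for another, so the sole guide is that compound 2 already sits at the limit of this assay after the halogen entered. The change from compound 2 to compound 3 is therefore expected to amount to an at least 1.3-fold lower number from compound 2 to compound 3 (0.12 log units; that floor lies within the scatter), with a fair chance that this assay again reports only a limit. The estimate for compound 3 in this assay is 150000 nM, with a range from 30000 nM to 400000 nM.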

Compound 3, half-maximal inhibitory concentration: 16100 nM
Estimate against measurement, compound 3: 9.3-fold (0.97 log units) above; the whole stated range lies above it.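

Exchanging one halogen for another at this place, an aromatic carbon para to a large group, is far from neutral: in this assay the change from fluoro to bromo gives an at least 12-fold lower number from compound 2 to compound 3 (1.09 log units; beyond the scatter), so the weak reading of compound 2 does not extend to every halogen placed here. Bromo and methoxy at this place cannot be told apart, with a 1.9-fold lower number from compound 1 to compound 3 (0.27 log units; within the scatter), and among the three groups shown fluoro alone stands apart from the others. The true size of the fluoro-to-bromo step remains unknown and only its floor can be read, because one end of it is not a number: the limit of > 200000 nM in this assay, at which 1 of the 3 values shown sits.

What the compounds leave open is whether chloro would read like bromo or like fluoro, and whether an amine or a carboxylic acid at this place would stay level with compound 1 and compound 3 or fall away as compound 2 does. Nor do they tell which feature separates fluoro from bromo and methoxy, and all three readings hold only for this one core.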